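Methoxy pattern on the shared core and cytotoxicity

This account rests on a few compounds, and the source may have more. Where it says the series, first, only, none or still open, it means among the compounds named here.

Compound 2 `COc1cc(-c2cc(/C=C/C(=O)c3ccc(N)cc3)[nH]n2)cc(OC)c1OC` gives 85% in a functional assay on A498 cells (Homo sapiens) for cytotoxicity, read by sulforhodamine B assay, with a stated time of 48 h, tested at 0.1 uM (on this read-out lower numbers stand for a stronger effect and higher numbers for a weaker effect at the one concentration tested), the lower of the two numbers in hand; compound 1 `COc1ccc(-c2cc(/C=C/C(=O)c3ccc(N)cc3)[nH]n2)cc1` gives 97% in this assay, a gap beyond the scatter. Compound 3 `COc1ccc(-c2cc(/C=C/C(=O)c3ccc(N)cc3)[nH]n2)cc1OC` awaits measurement in this assay. It differs from compound 2 by hydrogen in place of methoxy on an aromatic carbon. Among the measured compounds shown here, no measured pair shows this change, so its size is open. Compound 3 carries one methoxy group fewer than compound 2 and one more than compound 1. A small upward step, at the edge of the scatter, is expected as a number 6 percentage points higher from compound 2 to compound 3 (within the scatter). Compound 3 is estimated at 91%, between 80% and 100%.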

Compound 3, a percentage reported as activity, at one concentration (the size of the read-out at that concentration, not a potency): 80%
For compound 3 the middle estimate is 11 percentage points above the measured one; low and high end bracket the measured number.
By their numbers in this assay, from the lowest: compounds 3 and 2 (each within the scatter of the next); then compound 1.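

In this assay, among the compounds shown here, methoxy in place of hydrogen on an aromatic carbon of compound 1 gives a number 17 percentage points lower from compound 1 to compound 3 (beyond the scatter), the only step beyond the scatter. At the further place, ortho to a methoxy group and meta to a large group, hydrogen in place of methoxy gives a number 5 percentage points lower from compound 2 to compound 3 (within the scatter), so a methoxy there has no effect that can be told from scatter. Nothing at hand speaks to the cause of either step.

From the compounds shown here alone, whether a hydroxy group, an amine or a fluorine atom on this aromatic carbon would read differently from methoxy stays open. With a single concentration for each compound, the numbers speak only of a stronger or weaker effect at that concentration.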